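This account rests on a few compounds, and the source may have more. Where it says the series, first, only, none or still open, it means among the compounds named here.

Compound 1 `CCCCN1CCC(COC(c2ccccc2)c2ccccc2)CC1` gives 14000 nM in a functional assay on cells (T-cell line, Homo sapiens) for inhibition; on this read-out lower numbers stand for stronger inhibition and higher numbers for weaker inhibition.
Compound 2 `CCCCCN1CCC(COC(c2ccccc2)c2ccccc2)CC1` gives 10800 nM in this assay.
Compound 3 `CCCCCCCN1CCC(COC(c2ccccc2)c2ccccc2)CC1` gives 500 nM in this assay.

The three share one core and differ only in the chain on the ring nitrogen. The change from compound 1 to compound 2 is methyl in place of hydrogen on a saturated chain carbon, four bonds along the chain from an amine nitrogen in a ring, and it made a 1.3-fold lower number from compound 1 to compound 2 (0.11 log units; within the scatter). The cores of compound 1 and compound 3 differ by propyl in place of hydrogen on a saturated chain carbon, four bonds along the chain from an amine nitrogen in a ring, which gave a 28-fold lower number from compound 1 to compound 3 (1.45 log units; beyond the scatter); the neighbouring step is a 22-fold lower number from compound 2 to compound 3 (1.33 log units; beyond the scatter). Compound 4 `CCCCCCCCN1CCC(COC(c2ccccc2)c2ccccc2)CC1` is not yet measured and differs from compound 3 by methyl in place of hydrogen on a saturated chain carbon, seven bonds along the chain from an amine nitrogen in a ring. This is the same kind of change as that between compound 1 and compound 2, but it sits seven bonds along the chain rather than four. Because a 1.3-fold lower number from compound 1 to compound 2 (0.11 log units; within the scatter) lay within the scatter while a 22-fold lower number from compound 2 to compound 3 (1.33 log units; beyond the scatter) was large, the expected step is a 1.7-fold lower number from compound 3 to compound 4 (0.22 log units; within the scatter). Compound 4 is estimated at 300 nM, between 80 nM and 1200 nM.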

Compound 4, half-maximal inhibitory concentration: 700 nM
Compound 4: the middle estimate sits 2.3-fold (0.37 log units) below what was measured, and the stated range covers the measured number.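

In this assay, methyl in place of hydrogen on a saturated chain carbon carried from one core to another as a small step, with a 1.4-fold higher number from compound 3 to compound 4 (0.15 log units; within the scatter) set against the earlier one: the same change on two cores in this assay, a 1.3-fold lower number (0.11 log units; within the scatter) from compound 1 to compound 2 and a 1.4-fold higher number (0.15 log units; within the scatter) from compound 3 to compound 4, 1.8-fold (0.26 log units) apart, within the scatter of two such steps Propyl in place of hydrogen carried over as a large step, with a 15-fold lower number from compound 2 to compound 4 (1.19 log units; beyond the scatter) set against the earlier one: the same change on two cores in this assay, a 28-fold lower number (1.45 log units; beyond the scatter) from compound 1 to compound 3 and a 15-fold lower number (1.19 log units; beyond the scatter) from compound 2 to compound 4, 1.8-fold (0.26 log units) apart, within the scatter of two such steps The large gain also stands in a 20-fold lower number from compound 1 to compound 4 (1.30 log units; beyond the scatter), but these few pairs of chains show agreement only among the four compounds and do not show that either step would hold on a different core.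

The compounds shown leave open whether a longer chain than that of compound 4 would keep this level. They also leave open what a chain ending in an amine or a carboxylic acid would give.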